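The source may hold more compounds than are shown below. What is called first, only, known or untested is meant among the compounds shown, and "the series" means these compounds.

Working notes on the urea series. Among the compounds with values here, compound 1 `O=C(Nc1ccc(F)c(C(F)(F)F)c1)Nc1ccccn1` is the only member of the set with a number rather than a limit in an ADME assay on microsomes from liver (Homo sapiens) for metabolic stability, using NADPH, with a stated time of 60 min; a higher number here means faster removal of the compound, a lower number slower removal: compound 1 gives 188 uL/min. Compound 2 `N#Cc1ccc(NC(=O)Nc2ccc(F)c(C(F)(F)F)c2)cc1` reaches only the limit of this assay, with compound 2 at < 7 uL/min. Compound 3 `O=C(Nc1ccnc(C(F)(F)F)c1)Nc1ccc(F)c(C(F)(F)F)c1` likewise stops at the limit of this assay, compound 3 giving < 7 uL/min. The relevant point of reference is the limit of < 7 uL/min in this assay, at which 2 of the 3 values shown sit, so compound 1 sits well clear of the rest. Compound 4 `O=C(Nc1ccc(F)c(C(F)(F)F)c1)Nc1cnccn1` is not yet measured; it differs from compound 1 by pyrazin-2-yl in place of pyridin-2-yl on an amide-type nitrogen. A decrease in this assay is expected, of the size a 2.7-fold lower number from compound 1 to compound 4 (0.43 log units; beyond the scatter), beyond the usual scatter. For compound 4 the estimate is 70 uL/min, with a range from 20 uL/min to 220 uL/min.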

Compound 4, intrinsic clearance in a liver preparation (reported as CLH), per the amount of preparation that the assay uses: 210 uL/min
Beside the measured number, compound 4's estimate is 3.0-fold (0.48 log units) below it; measured number inside the range.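

At this place on the amide-type nitrogen, pyrazin-2-yl in place of pyridin-2-yl gives in this assay a 1.1-fold higher number from compound 1 to compound 4 (0.05 log units; within the scatter), so compound 1 and compound 4 cannot be told apart. A ring with 2 hetero atoms instead of 1 therefore does not bring compound 4 to the level where the read-out stops: the limit of < 7 uL/min in this assay, at which 2 of the 4 values shown sit.

Going by these compounds, whether an amine or a methoxy group on the pyrazin-2-yl ring would shift the number in this assay stays open. Which part of compound 4 the removal acts on also stays open.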